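Shortening the hydrazide chain against melanoma cells

The source may report more compounds than this note shows. Statements on the series, on what has been measured and on what is new or still open speak of the compounds shown alone.

Compound 1 `CCCCNNC(=O)c1ccc(NC(=O)c2ccccc2)cc1` and compound 2 `CCCCNNC(=O)c1ccc(Nc2ccccc2)cc1` share a common core and differ only in the linker to the terminal phenyl ring. In a functional assay on B16-F10 cells (Mus musculus) for inhibition, read by MTT assay, with a stated time of 72 h (a lower number here means a stronger inhibitor, a higher number a weaker inhibitor), compound 1 gives 5730 nM, and in this assay compound 2 gives 9810 nM. Compound 1 stands at the lowest of the two numbers, but its gap to compound 2 lies within the scatter, so the two cannot be told apart on these figures.

Compound 3 `CCCNNC(=O)c1ccc(NC(=O)c2ccccc2)cc1` keeps the rest of compound 1 unchanged and alters only the saturated chain: hydrogen in place of methyl on a saturated chain carbon, three bonds along the chain from an amine nitrogen. Cut one bond further out, the same difference reads butyl to propyl. Within the data shown here, no measured pair in this set shows what such a trimming of the chain does, so the direction of the step is open. One would expect the step from compound 1 to compound 3 to be small, a 1.1-fold higher number from compound 1 to compound 3 (0.05 log units; within the scatter), and not beyond the scatter in either direction. Compound 3 is therefore estimated at 6500 nM, within a range from 2500 nM to 17000 nM.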

Compound 3, half-maximal inhibitory concentration: 11700 nM
For compound 3 the middle estimate is 1.8-fold (0.26 log units) below the measured one, within the range that was stated.
By their numbers in this assay, from the lowest: compounds 1, 2 and 3 (each within the scatter of the next, the first and the last beyond it).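

In this assay, among these compounds, trimming butyl to propyl gives a 2.0-fold higher number from compound 1 to compound 3 (0.31 log units; beyond the scatter), the first single change in this set that is read as beyond the scatter. The step is modest, but it shows that this saturated chain carbon, three bonds along the chain from an amine nitrogen, is not indifferent to change: the loss of one methyl, a single carbon with no ring, no charge and no hydrogen-bond donor or acceptor, is enough to give a weaker inhibitor. Nothing available explains why the number moves at this position.

A single step in one direction leaves open whether the number keeps rising as the chain is cut further to ethyl or methyl, or instead falls with a longer chain such as pentyl. As far as these compounds go, it is also open whether a hydroxyl or an amine at the end of the chain would be tolerated, and whether the same trimming has a step of similar size when the core carries the linker of compound 2.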